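Changing the Halogens on the Benzyl Group of Compound 3

The source may hold more compounds than are shown below. What is called first, only, known or untested is meant among the compounds shown, and "the series" means these compounds.

In a functional assay on HepG2 cells (Homo sapiens) for antiproliferative activity, read by MTT assay, with a stated time of 48 h (on this read-out higher numbers stand for weaker inhibition and lower numbers for stronger inhibition), compound 3 (`Brc1cccc(CSc2nnc(-c3cnccn3)n2-c2ccccc2)c1`) gives 10600 nM and lies within the usual scatter of both its measured relatives. Those relatives share a core that differs from the core of compound 3: compound 1 (`Clc1ccc(CSc2nnc(-c3cnccn3)s2)cc1`) gives 6230 nM and compound 2 (`c1ccc(CSc2nnc(-c3cnccn3)s2)cc1`) gives 11400 nM so the three numbers cannot be ranked.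

Compound 4 (`Fc1cccc(F)c1CSc1nnc(-c2cnccn2)n1-c1ccccc1`) has not been measured yet. The change to it is 2,6-difluorophenyl in place of 3-bromophenyl on a saturated chain carbon bound to a sulfur and puts 2,6-difluorophenyl in place of 3-bromophenyl on a saturated chain carbon bound to a sulfur.

For the measured compounds named here, only one measured step bears on this, and only loosely. That step, a 1.8-fold higher number from compound 1 to compound 2 (0.26 log units; within the scatter) with hydrogen in place of chloro on an aromatic carbon, stays within the scatter. Going by the values given here, it also belongs to the other core, and no measured pair exchanges one halogen pattern for another. The evidence therefore gives no reason to expect a step beyond the scatter in this assay for this exchange. The estimated change is a 1.2-fold lower number from compound 3 to compound 4 (0.07 log units; within the scatter) and remains inside that scatter. For compound 4 the expected value is 9000 nM (estimated range 4000 nM to 22000 nM).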

Compound 4, half-maximal inhibitory concentration: 22600 nM
Estimate against measurement, compound 4: 2.5-fold (0.40 log units) below; the measured number lies above the stated range.
By their numbers in this assay, from the lowest: compounds 1, 3, 2 and 4 (each within the scatter of the next, the first and the last beyond it).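

In this assay, moving from 3-bromobenzyl to 2,6-difluorobenzyl on the shared core gives (a 2.1-fold higher number from compound 3 to compound 4 (0.33 log units; beyond the scatter)), the only step shown that lies beyond the scatter, and it points towards weaker inhibition. For the compounds shown here, the earlier step on the other core (a 1.8-fold higher number from compound 1 to compound 2 (0.26 log units; within the scatter)) stayed within the scatter, so this result is the first sign that the substituents on this ring can shift the read-out, though only modestly. The change alters the halogen, its number and its place on the ring all at once, and no measurement shown gives a reason for the rise.

On these data alone, it remains open which part of this exchange carries the step, and whether the same exchange would have a similar effect on the core of compound 1. A simple phenyl ring on the core of compound 3, or a ring bearing a methoxy group, an amine or a carboxylic acid, would show whether this position responds only to halogens or to other groups as well.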